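Benzyl(methyl)amino in place of 1H-indol-1-yl

The source may report more compounds than this note shows. Statements on the series, on what has been measured and on what is new or still open speak of the compounds shown alone.

Among the measured compounds shown here, in a functional assay on HL-60 cells (Homo sapiens) for inhibition, with a stated time of 72 h (on this read-out lower numbers stand for stronger inhibition and higher numbers for weaker inhibition), compound 1 (`[N-]=[N+]=NCc1ncnc2c1ncn2[C@@H]1O[C@H](CO)[C@@H](O)[C@H]1O`) gives 1880 nM and compound 2 (`OC[C@H]1O[C@@H](n2cnc3c(Cn4ccc5ccccc54)ncnc32)[C@H](O)[C@@H]1O`) gives 5700 nM as the higher of the two numbers so far. For the measured compounds named here, the one measured step is a 3.0-fold higher number from compound 1 to compound 2 (0.48 log units; beyond the scatter) with 1H-indol-1-yl in place of azido on a saturated chain carbon bound to an aromatic carbon; it is modest but beyond the scatter.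

Compound 3 (`CN(Cc1ccccc1)Cc1ncnc2c1ncn2[C@@H]1O[C@H](CO)[C@@H](O)[C@H]1O`) has benzyl(methyl)amino in place of 1H-indol-1-yl at that same place (benzyl(methyl)amino in place of 1H-indol-1-yl on a saturated chain carbon bound to an aromatic carbon). Going by the values given here, no measured step covers this exchange. Among the compounds with values here, the only guide is the modest size of a 3.0-fold higher number from compound 1 to compound 2 (0.48 log units; beyond the scatter) at this place, so a small shift at most is expected in this assay and none beyond the scatter, with no firm direction. The estimated step is a 1.3-fold lower number from compound 2 to compound 3 (0.10 log units; within the scatter) and stays within the scatter. For compound 3 the estimated value is 4500 nM with an expected range from 1500 nM to 14000 nM on this read-out.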

Compound 3, half-maximal inhibitory concentration: 5600 nM
Compound 3: the middle estimate sits 1.2-fold (0.09 log units) below what was measured; the range from low to high includes it.
By their numbers in this assay, from the lowest: compound 1; then compounds 3 and 2 (each within the scatter of the next).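

In this assay the exchange of 1H-indol-1-yl for benzyl(methyl)amino gives a 1.0-fold lower number from compound 2 to compound 3 (0.01 log units; within the scatter) and so separates the two groups by nothing that can be read, although one five-membered aromatic ring leaves and the count of heavy atoms stays the same. At this saturated chain carbon, the fused aromatic system of compound 2 is therefore not required to hold the level of this read-out, since the single six-membered aromatic ring of compound 3 serves equally. Azido now stands apart from both of these groups, with a 3.0-fold higher number from compound 1 to compound 3 (0.47 log units; beyond the scatter) as a second step of modest size beyond the scatter, and no measurement on hand explains this difference.

Going by these compounds, whether a primary amine, a hydroxyl or a simple methyl at this place would fall with azido or with the two larger groups remains open. So does whether a longer chain between the nitrogen and the phenyl ring of benzyl(methyl)amino would shift the number.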